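This account rests on a few compounds, and the source may have more. Where it says the series, first, only, none or still open, it means among the compounds named here.

Compound 3, `CC#CCn1c(N2CCC[C@@H](N)C2)cc(=O)n(Cc2cc(C(=O)O)ccc2Br)c1=O`, is the point of departure. In an assay on isolated protein for inhibition of Dipeptidyl peptidase 9 (Homo sapiens), read by fluorescence, with stated times of 15 min and 20 min (on this read-out higher numbers stand for weaker inhibition and lower numbers for stronger inhibition), compound 3 gives > 100 nM, which is a limit of the assay and not a number. Two measured compounds differ from compound 3 in one place each. Compound 1, `CC#CCn1c(N2CCC[C@@H](N)C2)cc(=O)n(Cc2cc(C(=O)OC)ccc2Br)c1=O`, carries methyl on an oxygen next to a carbonyl group where compound 3 carries hydrogen. In this assay compound 1 gives > 100 nM, again a limit. Compound 2, `CC#CCn1c(N2CCC[C@@H](N)C2)cc(=O)n(Cc2ccc(Cl)c(C(=O)O)c2)c1=O`, carries 3-carboxy-4-chlorophenyl where compound 3 carries 2-bromo-5-carboxyphenyl. In this assay compound 2 gives > 100 nM, also a limit. The step that the two limits leave unreadable from compound 1 to compound 3 and the step that the two limits leave unreadable from compound 2 to compound 3 are both of unreadable size, since (the limit of > 100 nM in this assay, at which 3 of the 3 values shown sit). Compound 4, `CC#CCn1c(N2CCC[C@@H](N)C2)cc(=O)n(Cc2cc(Br)cc(C(=O)O)c2)c1=O`, has not been measured; it differs from compound 3 as follows: 3-bromo-5-carboxyphenyl in place of 2-bromo-5-carboxyphenyl on a saturated chain carbon bound to an aromatic nitrogen. Within the data shown here, the only measured steps that bear on this change are the two unreadable ones, so no direction can be taken from them. Compound 4 is expected to give 300 nM, within a range from 100 nM to 1500 nM. The step that the limit leaves unreadable from compound 3 to compound 4 is thus expected to stay within the scatter, with compound 4 most likely also reported as a limit.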

Compound 4, half-maximal inhibitory concentration: > 100 nM
Compound 4: a limit, no number; the forecaster's own chance of this, stated with the estimate: 80%; the middle value does not contradict the limit.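

The steps from compound 3 to compound 4 and from compound 2 to compound 4 cannot be read, since both ends of each are limits: the limit of > 100 nM in this assay, at which 4 of the 4 values shown sit. The compounds shown leave open whether 3-bromo-5-carboxyphenyl and 2-bromo-5-carboxyphenyl differ at all in this assay.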